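Removing the Ethyl from the Side-Chain Oxygen

This account rests on a few compounds, and the source may have more. Where it says the series, first, only, none or still open, it means among the compounds named here.

Of the compounds shown here, three built on one shared core have been measured in a functional assay on MDA-MB-231 cells (Homo sapiens) for cytotoxicity, read by sulforhodamine B assay, with a stated time of 3 days; a higher number here means that more compound is needed for the effect, a lower number that less compound is needed. Compound 1 `CCOCc1c(C)coc1-c1ccc2c(c1OC)CCCC2(C)C` gives 42.7 uM, the lowest of the three numbers, although both other compounds sit within the scatter of it. Compound 2 `COC(=O)c1c(C)coc1-c1ccc2c(c1OC)CCCC2(C)C` gives 61 uM, and compound 3 `COc1c(-c2occ(C)c2COC(C)=O)ccc2c1CCCC2(C)C` gives 55.6 uM. The steps among them are all small: a 1.4-fold higher number from compound 1 to compound 2 (0.15 log units; within the scatter), a 1.3-fold higher number from compound 1 to compound 3 (0.11 log units; within the scatter) and a 1.1-fold lower number from compound 2 to compound 3 (0.04 log units; within the scatter).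

Compound 4 `COc1c(-c2occ(C)c2CO)ccc2c1CCCC2(C)C` differs from compound 1 in a single place: hydrogen in place of ethyl on an oxygen on a saturated carbon. The most direct precedent altered the same oxygen on a saturated carbon, acetyl in place of ethyl, and gave a 1.3-fold higher number from compound 1 to compound 3 (0.11 log units; within the scatter); a further change nearby, acetoxymethyl in place of methoxycarbonyl on an aromatic carbon, gave a 1.1-fold lower number from compound 2 to compound 3 (0.04 log units; within the scatter). Every alteration at this side chain has so far left this assay unmoved beyond the scatter, so for the loss of the ethyl no step beyond the scatter is expected in either direction. Compound 4 is therefore expected to give 45 uM, with a range from 20 uM to 100 uM. That estimate means a 1.1-fold higher number from compound 1 to compound 4 (0.02 log units; within the scatter), a step expected to remain within the scatter.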

Compound 4, concentration for half-maximal effect: 28.3 uM
Beside the measured number, compound 4's estimate is 1.6-fold (0.20 log units) above it; the measured number falls inside the stated range.
By their numbers in this assay, from the lowest: compounds 4, 1, 3 and 2 (each within the scatter of the next, the first and the last beyond it).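

In this assay, replacing the ethyl with hydrogen gives a 1.5-fold lower number from compound 1 to compound 4 (0.18 log units; within the scatter) and replacing the acetyl with hydrogen gives a 2.0-fold lower number from compound 3 to compound 4 (0.29 log units; within the scatter), so the free hydroxymethyl cannot be told apart from either capped form of this oxygen. The comparison with the ester gives a 2.2-fold lower number from compound 2 to compound 4 (0.33 log units; beyond the scatter), a modest step and the first among these compounds to pass beyond the scatter in this assay. Among the compounds shown here, this separates compound 4 from compound 2 alone, so exposing the oxygen on this saturated carbon costs nothing measurable here, and the hydroxymethyl is the first side chain to stand clearly apart from another.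

The compounds shown leave open whether an aminomethyl or a carboxylic acid in place of the hydroxymethyl would carry the number further in the same direction, or whether a longer chain such as propyl on this oxygen would stay within the scatter of compound 1. For the compounds shown here, they also leave open whether the single modest step would hold up in repeated measurements, and the reason for it cannot be stated, as nothing available bears on why these numbers differ.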